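Trifluoromethyl in place of methoxy: compound 1 to compound 3

The source may hold more compounds than are shown below. What is called first, only, known or untested is meant among the compounds shown, and "the series" means these compounds.

Compound 1 `COc1ccc(C(=O)Nc2nc3cc(OC)ccc3s2)cc1` was tested in a functional assay on MDA-MB-231 cells (Homo sapiens) for antiproliferative activity, read by sulforhodamine B assay; on this read-out higher numbers stand for weaker inhibition of growth and lower numbers for stronger inhibition of growth. In this assay compound 1 gives only a limit, > 10 ug/mL, so no number is known for it. Compound 2 `COc1ccc(NC(=O)Nc2nc3ccc(F)cc3s2)cc1` likewise gives only a limit in this assay, namely > 10 ug/mL. What the measurements show so far is the limit of > 10 ug/mL in this assay, at which 2 of the 2 values shown sit. Compound 3 `COc1ccc2sc(NC(=O)c3ccc(C(F)(F)F)cc3)nc2c1` differs from compound 1 by trifluoromethyl in place of methoxy on an aromatic carbon. Going by the values given here, no measured step of this kind exists, so no direction is known. The step that the limit leaves unreadable from compound 1 to compound 3 is expected to be none beyond the scatter. Compound 3 is therefore estimated at 15 ug/mL, from 4 ug/mL to 50 ug/mL.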

Compound 3, concentration for 50% growth inhibition: > 10 ug/mL
Compound 3: only a limit was reported; the forecaster's own chance of this, stated with the estimate: 75%; the middle value is on the limit's open side.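

Going by these compounds alone, compound 1 and compound 3 both give only a limit in this assay, so no step between them can be read. Still open is how strongly each compound inhibits growth, and whether trifluoromethyl in place of methoxy changes that; the values shown end at one point: the limit of > 10 ug/mL in this assay, at which 3 of the 3 values shown sit.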